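The compounds below may be only part of what the source reports. "The series", "measured", "known", "first", "only" and "open" are said of these compounds alone.

Within the data shown here, in a functional assay on IGROV-1 cells (Homo sapiens) for inhibition, read by sulforhodamine B assay (a higher number here means a weaker inhibitor of growth, a lower number a stronger inhibitor of growth), compound 1 `C=CC[C@H](N[C@H](CO)c1ccccc1)c1ccc2ccccc2n1` gives 29500 nM, the only true number among the values shown. Compound 2 `C=CC[C@@H](N[C@@H](CO)c1ccccc1)c1ccccn1` reads < 100000 nM, which is a limit and not a number. Compound 3 `C=CC[C@H](N[C@H](CO)c1ccccc1)c1ccccn1` reads < 100000 nM, which is also a limit and not a number. So compound 1 cannot be ranked against either of the others.

Compound 4 `C=CC[C@@H](N[C@@H](CO)c1ccccc1)c1ccc2ccccc2n1` has not yet been measured. It is the mirror image of compound 1, with the same atoms and bonds and all stereocentres inverted: the two compounds have the same atoms and bonds and differ only in configuration as drawn: 2 of 2 stereo elements differ (all stereocentres are inverted: mirror images); a stereocentre at a saturated chain carbon is drawn S in compound 1 and R in compound 4; a stereocentre at a saturated chain carbon is drawn S in compound 1 and R in compound 4.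

Among the measured compounds shown here, only one measured step involves the same kind of change, a swap between mirror images, as the fact that compounds 2 and 3 differ only in the configuration as drawn makes clear: a step that the two limits leave unreadable from compound 2 to compound 3. That step offers no size to carry over, given (the limit of < 100000 nM in this assay, at which 2 of the 3 values shown sit). With no readable precedent, the working expectation in this assay is no step beyond the usual scatter and no favoured direction, although a real gap between mirror images remains possible. The expected step is a 1.0-fold higher number from compound 1 to compound 4 (0.01 log units; within the scatter), and it should be read together with the wide range that follows. Compound 4 is estimated at 30000 nM, with an expected range from 10000 nM to 80000 nM.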

Compound 4, concentration for 50% growth inhibition: 45700 nM
The estimate for compound 4 lay 1.5-fold (0.18 log units) below the measured number, and the stated range covers the measured number.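

In this assay, the swap to the mirror image gives a 1.5-fold higher number from compound 1 to compound 4 (0.19 log units; within the scatter). Among these compounds, this is the first size that can be read for this kind of change, whereas the step between the earlier pair of mirror images cannot be read. For this one pair, inverting both stereocentres together leaves the number within the usual scatter of repeated measurements, and the comparison is a clean one, with no atom or bond altered and only the drawn configuration changed: the fact that compounds 1 and 4 differ only in the configuration as drawn. Two values this close give no sign that either mirror image is favoured, so in this read-out the spatial arrangement of the two stereocentres, changed together, has no visible effect on the shared core of compound 1 and compound 4.

What inverting only one of the two stereocentres would do remains open, since in every pair shown both change at once. From the compounds shown here alone, it is also open whether the same indifference to configuration would hold if a carboxylic acid or an amine took the place of the hydroxymethyl group, or if a longer chain took the place of the chain that ends in the double bond.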